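Phenyl for Cyclobutyl: Estimating Compound 4

The source may hold more compounds than are shown below. What is called first, only, known or untested is meant among the compounds shown, and "the series" means these compounds.

Measured in a functional assay for inhibition of sodium/hydrogen exchanger (Oryctolagus cuniculus); a higher number here means a weaker inhibitor, a lower number a stronger inhibitor:
Compound 1 `Cc1cc(Cl)c(S(C)(=O)=O)cc1C(=O)N=C(N)N`: 25 nM
Compound 2 `Cc1cc(Br)c(S(C)(=O)=O)cc1C(=O)N=C(N)N`: 12 nM
Compound 3 `Cc1cc(C2CCC2)c(S(C)(=O)=O)cc1C(=O)N=C(N)N`: 8.2 nM

Compound 3 gives the lowest of these three numbers; the step from compound 1 to compound 3 was a 3.0-fold lower number from compound 1 to compound 3 (0.48 log units; beyond the scatter), while the step from compound 2 to compound 3 was a 1.5-fold lower number from compound 2 to compound 3 (0.17 log units; within the scatter). Compound 4 `Cc1cc(-c2ccccc2)c(S(C)(=O)=O)cc1C(=O)N=C(N)N` differs from compound 3 by one change: phenyl in place of cyclobutyl on an aromatic carbon. Within the data shown here, the steps that bear on this are a 2.1-fold lower number from compound 1 to compound 2 (0.32 log units; beyond the scatter) and a 3.0-fold lower number from compound 1 to compound 3 (0.48 log units; beyond the scatter), both modest and both in the direction of lower numbers; the step of a 1.5-fold lower number from compound 2 to compound 3 (0.17 log units; within the scatter) shows that exchanging one such group for another can leave the number unchanged. Among the measured compounds shown here, no measured step covers phenyl itself. Compound 4 is therefore expected to change only a little, a 1.0-fold lower number from compound 3 to compound 4 (0.01 log units; within the scatter), in this assay. The estimate for compound 4 is 8 nM, with a range from 3 nM to 25 nM.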

Compound 4, half-maximal inhibitory concentration: 19 nM
Estimate against measurement, compound 4: 2.4-fold (0.38 log units) below; the range from low to high includes it.
By their numbers in this assay, from the lowest: compounds 3, 2, 4 and 1 (each within the scatter of the next, the first and the last beyond it).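

In this assay, among these compounds, phenyl in place of cyclobutyl is the first change at this position to give a higher number beyond the scatter, a 2.3-fold higher number from compound 3 to compound 4 (0.36 log units; beyond the scatter), so not every carbon ring here matches cyclobutyl. Phenyl in place of bromo gives a 1.6-fold higher number from compound 2 to compound 4 (0.20 log units; within the scatter), and phenyl in place of chloro gives a 1.3-fold lower number from compound 1 to compound 4 (0.12 log units; within the scatter), so both of these steps stay within the scatter. No measurement available here explains these differences. Going by these compounds, whether an amine, a carboxylic acid or a longer chain would be tolerated at this position remains open. So does whether cyclohexyl would track cyclobutyl or phenyl.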